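Methoxypyrimidinyl in place of methoxyphenyl on the shared core

A few compounds are considered here, and "the series" means these few. Any claim that something is new, unique, unknown or untested is made for them only; others in the source may bear on it.

Compound 1 `COc1ccc(-n2cnc3cnc(-c4ccc(F)cc4C)cc32)cc1` stands at the top of the two numbers recorded so far: in an ADME assay on S9 fraction from liver (Mus musculus) for metabolic stability, read by LC-MS, using NADPH, with a stated time of 45 min, tested at 3 uM, in the presence of a further agent that is not named here (a lower number here means that the liver removes a smaller share, a higher number that the liver removes a larger share of the compound in one pass), compound 1 gives 1. Compound 2 `Cc1cc(F)ccc1-c1cc2c(cn1)ncn2-c1ccc(S(C)(=O)=O)cc1` gives 0.07, and the step a number 0.93 lower from compound 1 to compound 2 (beyond the scatter) came with methylsulfonyl in place of methoxy on an aromatic carbon. Compound 3 `COc1ccc(-n2cnc3cnc(-c4ccc(F)cc4C)cc32)cc1C(C)C` has no result: in this assay compound 3 gives "not determined" (no result reported). Compound 4 `COc1ncc(-n2cnc3cnc(-c4ccc(F)cc4C)cc32)cn1` differs from compound 1 by 2-methoxypyrimidin-5-yl in place of 4-methoxyphenyl on an aromatic nitrogen. No measured step touches this part of the core, so the one step shown only tells that changes on the ring attached to the ring nitrogen can move this number a great deal. With compound 1 already at the ceiling, a downward step is expected, estimated as a number 0.30 lower from compound 1 to compound 4 (beyond the scatter), giving compound 4 an expected 0.7 between 0.35 and 1.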

Compound 4, hepatic extraction ratio in the Mus musculus assay: 0.11
Estimate against measurement, compound 4: 0.59 above, outside the stated range (below it).
By their numbers in the Mus musculus assay, from the lowest: compounds 2 and 4 (each within the scatter of the next); then compound 1.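

In the Mus musculus assay, changing the ring attached to the ring nitrogen from 4-methoxyphenyl to 2-methoxypyrimidin-5-yl, with the methoxy group kept, brings a number 0.89 lower from compound 1 to compound 4 (beyond the scatter). So the atoms of this ring matter here, not only the group it carries. In a physicochemical assay for solubility (a lower number here means a less soluble compound, a higher number a more soluble compound), compound 1 gives 117000 nM. In the physicochemical assay compound 4 gives > 200000 nM, which is a limit of the assay and not a number.

The compounds shown leave open whether a methoxypyridinyl group would give a similar step in the Mus musculus assay, and how an amine in place of the methoxy group would fare.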